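The source may hold more compounds than are shown below. What is called first, only, known or untested is meant among the compounds shown, and "the series" means these compounds.

Compound 1 `NC[C@@H]1C[C@@]1(C(=O)N1C=CCCC1)c1ccsc1` and compound 2 `CCN(CC)C(=O)[C@@]1(c2ccsc2)C[C@H]1CNC` share a core. In an assay on HEK293 cells for inhibition of sodium-dependent dopamine transporter (Homo sapiens) (a higher number here means a weaker inhibitor, a lower number a stronger inhibitor), compound 1 gives > 10000 nM, which is a limit of the assay rather than a number. Compound 2 likewise gives only the limit > 10000 nM in this assay. On the numbers shown, compound 2 stands at the limit of > 10000 nM in this assay, at which 2 of the 2 values shown sit. Compound 3 `CCN(CC)C(=O)[C@@]1(c2ccsc2)C[C@H]1CN(C)C` differs from compound 2 by methyl in place of hydrogen on an amine nitrogen. Among the compounds with values here, no step between measured compounds is available, so the size of this change cannot be read from the data; a step no larger than the scatter seems the likelier outcome. Compound 3 is therefore expected to remain weak, at about 20000 nM (range 6000 nM to 60000 nM). The step this estimate implies, a step that the limit leaves unreadable from compound 2 to compound 3, is expected to stay within scatter.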

Compound 3, half-maximal inhibitory concentration: > 10000 nM
Compound 3 was reported as a limit; the forecaster's own chance of this, stated with the estimate: 80%; the middle value lies beyond the limit too.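

Within the data shown here, compound 2 and compound 3 both give only a limit of the assay, and no step between them can be read. The compounds shown leave open how strongly each one actually inhibits in this assay, and whether the added methyl changes that.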